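Aryl swap on the triazole nitrogen of the spiro series

This account rests on a few compounds, and the source may have more. Where it says the series, first, only, none or still open, it means among the compounds named here.

Within the data shown here, compound 2 `N#CC1=C(N)Oc2c(N)cc3nc4ccccc4nc3c2C12C(=O)N(Cc1cnnn1-c1cccc(Br)c1)c1ccccc12` holds the only numeric value in hand: in a functional assay on A549 cells (Homo sapiens) for antiproliferative activity, read by MTT assay, with a stated time of 48 h (a higher number here means a weaker inhibitor, a lower number a stronger inhibitor), compound 2 gives 18900 nM. Compound 1 `Cc1ccc(C)c(-n2nncc2CN2C(=O)C3(C(C#N)=C(N)Oc4c3c3nc5ccccc5nc3c3ccccc43)c3ccccc32)c1` reaches only a limit of the assay, > 50000 nM, which is a limit and not a number; see (the limit of > 50000 nM in this assay, at which 1 of the 2 values shown sits). Compound 3 `N#CC1=C(N)Oc2c(N)cc3nc4ccccc4nc3c2C12C(=O)N(Cc1cnnn1-c1c(F)cccc1F)c1ccccc12` differs from compound 2 by 2,6-difluorophenyl in place of 3-bromophenyl on an aromatic nitrogen. Among the measured compounds shown here, no step between measured compounds exists, so nothing sets the size of this change; none beyond the scatter is expected in this assay. Compound 3 is expected near 22000 nM, between 8000 nM and 50000 nM. The expected step is a 1.2-fold higher number from compound 2 to compound 3 (0.07 log units; within the scatter).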

Compound 3, half-maximal inhibitory concentration: > 50000 nM
Compound 3 gave a limit, no number (the forecaster's own chance of this, stated with the estimate: 25%); at least 2.2-fold (0.35 log units) between middle value and limit.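

Among these compounds, on an aromatic nitrogen of the series, the choice of aryl group registers in this assay: 2,6-difluorophenyl in place of 3-bromophenyl gives an at least 2.6-fold higher number from compound 2 to compound 3 (0.42 log units; beyond the scatter), the first step and one beyond the scatter. Compound 3 stands at a limit and not a number, so the step has a lower bound only: the limit of > 50000 nM in this assay, at which 2 of the 3 values shown sit.

Open, from the compounds shown here alone, is how an unsubstituted phenyl, a 3-chlorophenyl or a 3-aminophenyl would read at this position. Also open, going by these compounds, is whether any group here gives a number lower than that of compound 2.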